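Series notes: oxazolidinedione pair, liver microsome stability

The source may report more compounds than this note shows. Statements on the series, on what has been measured and on what is new or still open speak of the compounds shown alone.

Measured so far:
compound 1 `COc1cc(OC)cc(-c2cnc([C@@]3(Cc4ccccc4)OC(=O)N([C@H](C)c4ccccc4)C3=O)[nH]2)c1` — 43%
compound 2 `C[C@H](c1ccccc1)N1C(=O)O[C@](Cc2ccccc2)(c2nnc(Cc3ccccc3)o2)C1=O` — 7%

In an ADME assay (liver) for metabolic stability, with Liver microsome (Homo sapiens) as the target, using microsomes, with a stated time of 0.5 h, tested at 1 uM (on this read-out lower numbers stand for a less stable compound and higher numbers for a more stable compound), compound 1 gives 43%. Compound 2 gives 7% in this assay, the lower of the two numbers, and the gap to compound 1 is beyond the scatter. Compound 1 and compound 2 differ in more than one place, so no single structural step can be read from that pair; the two values are simply what they show.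

Compound 3 `COc1cc(OC)nc(-c2nnc([C@@]3(Cc4ccccc4)OC(=O)N([C@H](C)c4ccccc4)C3=O)o2)n1` is not yet measured. It differs from compound 2 in one place: 4,6-dimethoxypyrimidin-2-yl in place of benzyl on an aromatic carbon. Among the measured compounds shown here, no measured pair in the set isolates this change, so the size of the step rests on judgment alone. The nearest point of reference is compound 1, which carries two methoxy groups on its aryl ring and gives 43%, well above compound 2.

The step from compound 2 to compound 3 is expected to be an increase in this assay, a number 23 percentage points higher from compound 2 to compound 3 (beyond the scatter), beyond the scatter but with wide uncertainty. Compound 3 is estimated at 30%, within 10% to 60%.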

Compound 3, percent of the compound remaining: 31%
Compound 3: middle estimate off by 1 percentage points, on the low side; the measured number falls inside the stated range.
By their numbers in this assay, from the lowest: compound 2; then compound 3; then compound 1.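

In this assay, among the compounds shown here, the exchange of benzyl for 4,6-dimethoxypyrimidin-2-yl gives a number 24 percentage points higher from compound 2 to compound 3 (beyond the scatter) and provides the first reading of a change in one place. The aromatic carbon of the five-membered aromatic ring with 2 nitrogen and 1 oxygen is therefore a position where the group affects this read-out, with the rest of the structure held constant. The entering group differs from benzyl in several counted ways at once, with a six-membered aromatic ring carrying 2 hetero atoms and 4 hydrogen-bond acceptors in place of a carbon-only ring and none, and no measurement available here links the step to any one of these differences.

The compounds shown leave open whether the step depends on the two methoxy groups, the ring nitrogens or both, which a phenyl, a 3,5-dimethoxyphenyl or an unsubstituted pyrimidin-2-yl group on this carbon would help to separate. Also open, on these data alone, is how a group of another kind at this position, such as an amine or a carboxylic acid, would read in this assay on the shared core.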